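Replacing dimethylcarbamoyl with 1,1-difluoroethyl on a shared core

The compounds below may be only part of what the source reports. "The series", "measured", "known", "first", "only" and "open" are said of these compounds alone.

Measured so far in an ADME assay on the whole organism (strain 129/SvEvBrd x C57BL/6) for metabolic stability, with Mus musculus as the target; on this read-out higher numbers stand for a longer-lived compound and lower numbers for a shorter-lived compound:
- compound 1 `CC(O)c1nc([C@@H](O)[C@H](O)[C@H](O)CO)c[nH]1`: 4.4 h
- compound 2 `CC(=O)N/N=C(\C)c1nc([C@@H](O)[C@H](O)[C@H](O)CO)c[nH]1`: 2.6 h
- compound 3 `CN(C)C(=O)c1nc([C@@H](O)[C@H](O)[C@H](O)CO)c[nH]1`: 4 h

Compound 3, at 4 h, is not clearly separated from the other two. Its gaps to compound 1 and to compound 2 both lie within the usual scatter of repeated measurements, so this assay does not rank these three.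

Compound 4 `CC(F)(F)c1nc([C@@H](O)[C@H](O)[C@H](O)CO)c[nH]1` has not been measured yet. Compared with compound 3, it carries 1,1-difluoroethyl in place of dimethylcarbamoyl on an aromatic carbon.

Within the data shown here, only one measured step bears on this change. That step, a 1.1-fold lower number from compound 1 to compound 3 (0.04 log units; within the scatter), put dimethylcarbamoyl in place of 1-hydroxyethyl on an aromatic carbon, and it stayed within the scatter. Among the measured compounds shown here, no measured compound carries 1,1-difluoroethyl, so this evidence is thin and the range has to stay wide. No shift beyond the scatter is expected, and the data favour no clear direction. The expected change is a 1.1-fold lower number from compound 3 to compound 4 (0.05 log units; within the scatter). For compound 4 the estimated half-life is 3.6 h, with an expected range from 1.8 h to 7 h.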

Compound 4, half-life: 1 h
For compound 4 the middle estimate is 3.6-fold (0.56 log units) above the measured one; the whole stated range lies above it.
By their numbers in this assay, from the lowest: compound 4; then compounds 2, 3 and 1 (each within the scatter of the next).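

In this assay, the 1-hydroxyethyl and dimethylcarbamoyl groups could not be told apart at this ring carbon, so the position might have seemed to tolerate any change without effect on lifetime. The 1,1-difluoroethyl group ends that impression, giving a 4.0-fold lower number from compound 3 to compound 4 (0.60 log units; beyond the scatter) and a 4.4-fold lower number from compound 1 to compound 4 (0.64 log units; beyond the scatter) as the first differences in this set that stand clear of the scatter. The group on this aromatic carbon, between two ring nitrogen atoms, can therefore shorten the half-life in the whole mouse, although both steps are only modest, and no measurement shown here explains why compound 4 stands lowest.

As far as these compounds go, whether the fall comes with the fluorine atoms stays open: a plain ethyl group on the shared core would show whether a small carbon chain without fluorine lasts as long as compound 1 or as briefly as compound 4. From the compounds shown here alone, how a carboxylic acid or an amine at this carbon would behave is also open, as is whether the same replacement would shorten the half-life on a different core.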